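A few compounds are considered here, and "the series" means these few. Any claim that something is new, unique, unknown or untested is made for them only; others in the source may bear on it.

Working notes on a set of sulfonamides built on one shared core.

Compound 1 `Cc1cccc(S(=O)(=O)Nc2ccc3oc(-c4ccccc4)nc3c2)c1` carries a 3-methylphenyl on the sulfonyl sulfur. In an assay on isolated protein for inhibition of malate dehydrogenase, mitochondrial (Sus scrofa), with stated times of 45 min and 30 min (a lower number here means a stronger inhibitor, a higher number a weaker inhibitor), compound 1 gives > 63000 nM, which is a limit of the assay and not a number. Compound 2 `COc1cccc(S(=O)(=O)Nc2ccc3oc(-c4ccccc4)nc3c2)c1` differs by methoxy in place of methyl on an aromatic carbon; in this assay compound 2 gives > 63000 nM, again only a limit. Compound 3 `O=S(=O)(Nc1ccc2oc(-c3ccccc3)nc2c1)c1cccc(O)c1` has hydroxy in place of methyl on an aromatic carbon; in this assay compound 3 gives > 63000 nM, also a limit. All three values sit at the limit of > 63000 nM in this assay, at which 3 of the 3 values shown sit, so compound 3 stands level with the others as far as the numbers allow. The measured steps are accordingly unreadable: a step that the two limits leave unreadable from compound 1 to compound 2, a step that the two limits leave unreadable from compound 1 to compound 3 and a step that the two limits leave unreadable from compound 2 to compound 3.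

Compound 4 `O=S(=O)(Nc1ccc2oc(-c3ccccc3)nc2c1)c1ccc(Cl)cc1` is the next member. The change is 4-chlorophenyl in place of 3-hydroxyphenyl on a sulfonyl sulfur. Going by the values given here, none of the measured steps gives a readable size, so none bears on this change beyond showing that variation on the sulfonyl aryl has so far left every compound at the limit.

For compound 4 the expected value in this assay is therefore 70000 nM, with a range from 20000 nM to 300000 nM. The step from compound 3 to compound 4 is expected to be a step that the limit leaves unreadable from compound 3 to compound 4, and a further limit rather than a number is the likelier outcome.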

Compound 4, half-maximal inhibitory concentration: > 63000 nM
Compound 4: no number, only a limit; the forecaster's own chance of this, stated with the estimate: 75%; the middle value does not contradict the limit.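

In this assay compound 4 gives > 63000 nM, which is a limit and not a number. The steps to compound 4 from compound 1, compound 2 and compound 3 cannot be read, as all four compounds stand at the same limit: the limit of > 63000 nM in this assay, at which 4 of the 4 values shown sit. The compounds shown leave open how far apart these four lie, and whether any group on the sulfonyl sulfur of the shared core gives a readable value in this assay.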